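Cytotoxicity notes: aryl change from compound 2 to compound 3

This account rests on a few compounds, and the source may have more. Where it says the series, first, only, none or still open, it means among the compounds named here.

Measured so far in an ADME assay on L6 cells (Rattus norvegicus) for cytotoxicity, read by resazurin assay, with a stated time of 72 h; a lower number here means that less compound is needed, a higher number that more compound is needed for the effect:
- compound 1 `CCOC(=O)C1=C(O)/C(=C\c2cc(C)n(-c3ccc(F)cc3)c2C)N=C1C` gives 140000 nM
- compound 2 `CCOC(=O)C1=C(C)N/C(=C/c2cc(C)n(-c3ccc(F)cc3F)c2C)C1=O` gives 14000 nM

Compound 2 holds the lower of the two numbers, and its gap to compound 1 lies beyond the usual scatter. For the measured compounds named here, no measured pair differs in one place only, so the size of a single change on the aromatic nitrogen remains unknown in this assay.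

Compound 3 `CCOC(=O)C1=C(C)N/C(=C/c2cc(C)n(-c3ccc(OC)cc3)c2C)C1=O` is still unmeasured and carries 4-methoxyphenyl in place of 2,4-difluorophenyl on an aromatic nitrogen relative to compound 2. Going by the values given here, the only reference point is compound 1 at 140000 nM in this series, which stands higher, so a modest upward move is expected. The expected step is a 2.5-fold higher number from compound 2 to compound 3 (0.40 log units; beyond the scatter) in this estimate, though it may not clear the scatter. For compound 3 the estimated value is 35000 nM with an expected range of 11000 nM to 110000 nM in this assay.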

Compound 3, half-maximal effective concentration: 140000 nM
Beside the measured number, compound 3's estimate is 4.0-fold (0.60 log units) below it, outside the stated range (above it).
By their numbers in this assay, from the lowest: compound 2; then compounds 1 and 3 (each within the scatter of the next).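

In this assay, the group on the aromatic nitrogen now has a measured effect of its own: with the rest of the structure unchanged, 4-methoxyphenyl in place of 2,4-difluorophenyl gives a 10-fold higher number from compound 2 to compound 3 (1.00 log units; beyond the scatter). For the compounds shown here, this is the first single-place step, and it shows that the number responds to the aryl substituents at this position. The swap keeps the heavy-atom count and the single aromatic ring, while the entering group carries one hydrogen-bond acceptor and the leaving group none. No measured property in hand accounts for the step.

The swap removes both fluorines and adds the methoxy group at once, so their separate shares cannot be read. From the compounds shown here alone, how a plain phenyl or a 4-aminophenyl would stand on the same nitrogen remains open.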